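Swapping the Benzylamine Linker for a Dichlorophenyl Thioether

The source may report more compounds than this note shows. Statements on the series, on what has been measured and on what is new or still open speak of the compounds shown alone.

The measured compounds and their values:
Compound 1, `Nc1cc(N)c2nc(-c3ccccc3)c(NCc3ccc(Cl)c(Cl)c3)nc2c1`, 4900 nM.
Compound 2, `Nc1cc(N)c2nc(-c3ccccc3)c(NCc3ccc(F)cc3)nc2c1`, < 100000 nM.
Compound 3, `COc1ccc(CNc2nc3cc(N)cc(N)c3nc2-c2ccccc2)cc1`, 21900 nM.

Three compounds share one core and differ only in the group attached to it. In a functional assay on NCI-H522 cells (Homo sapiens) for inhibition, read by sulforhodamine B assay, with a stated time of 48 h (on this read-out lower numbers stand for stronger inhibition of growth and higher numbers for weaker inhibition of growth), compound 1 gives 4900 nM. For compound 2 the assay reports only a limit, < 100000 nM, and not a number. Compound 3 gives 21900 nM in this assay. Going by the values given here, the one readable step is a 4.5-fold higher number from compound 1 to compound 3 (0.65 log units; beyond the scatter). The two steps touching compound 2, a step that the limit leaves unreadable from compound 1 to compound 2 and a step that the limit leaves unreadable from compound 2 to compound 3, cannot be sized, because of the limit of < 100000 nM in this assay, at which 1 of the 3 values shown sits.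

Compound 4, `Nc1cc(N)c2nc(-c3ccccc3)c(Sc3ccc(Cl)c(Cl)c3)nc2c1`, has not been measured. It differs from compound 2 by (3,4-dichlorophenyl)sulfanyl in place of (4-fluorobenzyl)amino on an aromatic carbon. Compound 4 thus carries the same 3,4-dichlorophenyl ring as compound 1, but joined to the core through sulfur rather than through a nitrogen and a saturated carbon. Among the compounds with values here, no measured step shows what that change of linker does, so the expectation rests mainly on compound 1 and its value 4900 nM, with wide room on either side. Compound 4 is expected to come in near 10000 nM, somewhere between 2000 nM and 60000 nM. That estimate means a step that the limit leaves unreadable from compound 2 to compound 4, whose size stays unreadable from the limit of compound 2.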

Compound 4, concentration for total growth inhibition: 33900 nM
Compound 4: middle estimate off by 3.4-fold (0.53 log units), on the low side; measured number inside the range.
By their numbers in this assay, from the lowest: compound 1; then compounds 3 and 4 (each within the scatter of the next).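

No new step can be read for compound 4, because the only compound it is paired with, compound 2, carries a limit and not a number: the limit of < 100000 nM in this assay, at which 1 of the 4 values shown sits.

The compounds shown leave open how far compound 2 lies from compound 4 in this assay, and so what (3,4-dichlorophenyl)sulfanyl in place of (4-fluorobenzyl)amino does to growth inhibition.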